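The Same Trimming at the Ring Nitrogen, Tried Twice

The compounds below may be only part of what the source reports. "The series", "measured", "known", "first", "only" and "open" are said of these compounds alone.

Compound 1 `Cc1ccc(-n2nc(C(C)(C)C)cc2NC(=O)Nc2cc(C(F)(F)F)cc(C(F)(F)F)c2)cc1` and compound 2 `Cn1nc(C(C)(C)C)cc1NC(=O)Nc1cc(C(F)(F)F)cc(C(F)(F)F)c1` share a core and differ by methyl in place of 4-methylphenyl on an aromatic nitrogen. In an assay on isolated protein for inhibition of serine/threonine-protein kinase 10 (Homo sapiens), read by thermal shift assay, tested at 10 uM (on this read-out higher numbers stand for stronger stabilisation of the target against heat and lower numbers for weaker stabilisation of the target), compound 1 gives -0.5 degrees C, and compound 2 gives 1.1 degrees C; the step is a number 1.6 degrees C higher from compound 1 to compound 2 (beyond the scatter). Compound 3 `Cc1ccc(-n2nc(C(C)(C)C)cc2NC(=O)Nc2cc(F)cc(F)c2)cc1` carries a different urea end; the difference between its core and that of compound 1 is not broken down here. In this assay compound 3 gives 0.6 degrees C, which lies within the scatter of compound 2 and beyond the scatter above compound 1. Going by the values given here, compound 4 `Cn1nc(C(C)(C)C)cc1NC(=O)Nc1cc(F)cc(F)c1` follows from compound 3 by methyl in place of 4-methylphenyl on an aromatic nitrogen, the same change as the one between compound 1 and compound 2. In this assay, among the compounds with values here, the step from compound 3 to compound 4 is expected to resemble the earlier one, because a number 1.6 degrees C higher from compound 1 to compound 2 (beyond the scatter) is the only guide available, giving an estimated a number 1.2 degrees C higher from compound 3 to compound 4 (beyond the scatter). Compound 4 is therefore expected to give 1.8 degrees C, between 0.3 degrees C and 3.3 degrees C.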

Compound 4, shift of the target's melting temperature: 1.1 degrees C
Compound 4: middle estimate off by 0.70 degrees C, on the high side; the measured number falls inside the stated range.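

In this assay the change on the second core comes out as a number 0.50 degrees C higher from compound 3 to compound 4 (within the scatter). Set beside the first case, the two steps cannot be told apart: the same change on two cores in this assay, a number 1.6 degrees C higher (beyond the scatter) from compound 1 to compound 2 and a number 0.50 degrees C higher (within the scatter) from compound 3 to compound 4, 1.1 degrees C apart, within the scatter of two such steps. This shows no measurable dependence of the step on the urea end across these two pairs, but it does not show that the step is the same on both cores, as only the first step lies beyond the scatter, and two cores cannot speak for the whole series.

The compounds shown leave open how an ethyl group or a longer chain ending in an amine on that aromatic nitrogen would compare with methyl. They also leave open whether the step holds with a urea end carrying a nitrile or a carboxylic acid.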